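Thiophen-3-yl Replaces 2,4-Difluorophenyl on the Shared Core

This account rests on a few compounds, and the source may have more. Where it says the series, first, only, none or still open, it means among the compounds named here.

In a functional assay on HCT-116 cells (Homo sapiens) for antiproliferative activity, with a stated time of 72 h (a higher number here means a weaker inhibitor, a lower number a stronger inhibitor), compound 1 (`Nc1ncnn2c([C@@H]3O[C@H](CO)[C@@H](O)[C@H]3O)cc(-c3ccccc3)c12`) gives 82600 nM and compound 2 (`Nc1ncnn2c([C@@H]3O[C@H](CO)[C@@H](O)[C@H]3O)cc(-c3ccc(F)cc3F)c12`) gives 59500 nM. For the measured compounds named here, compound 2 therefore stands level with compound 1, the only other measured compound. In compound 3 (`Nc1ncnn2c([C@@H]3O[C@H](CO)[C@@H](O)[C@H]3O)cc(-c3ccsc3)c12`), thiophen-3-yl takes the place of 2,4-difluorophenyl on an aromatic carbon: thiophen-3-yl in place of 2,4-difluorophenyl on an aromatic carbon.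

Going by the values given here, only one measured step bears on this change, a 1.4-fold lower number from compound 1 to compound 2 (0.14 log units; within the scatter), and it exchanged one six-membered aromatic ring for another. Among the compounds with values here, no measured step replaces that ring with a five-membered aromatic ring, so the evidence is thin. No step beyond the scatter is expected in this assay, although a wide range is warranted. The expected step is a 1.5-fold lower number from compound 2 to compound 3 (0.17 log units; within the scatter). Compound 3 is estimated at 40000 nM, with an expected range of 4000 nM to 100000 nM.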

Compound 3, half-maximal inhibitory concentration: 45200 nM
Compound 3: the middle estimate sits 1.1-fold (0.05 log units) below what was measured; the measured number falls inside the stated range.
By their numbers in this assay, from the lowest: compounds 3, 2 and 1 (each within the scatter of the next).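

In this assay, the position on the aromatic carbon of the shared core now carries a five-membered aromatic ring with a sulfur atom as well as the earlier six-membered rings of carbon only. The exchange gives a 1.3-fold lower number from compound 2 to compound 3 (0.12 log units; within the scatter) and a 1.8-fold lower number from compound 1 to compound 3 (0.26 log units; within the scatter). Neither the change in ring size nor the hetero atom therefore moves the number beyond the scatter, and compounds 1, 2 and 3 stand level. Nothing measured on these compounds accounts for this result.

From the compounds shown here alone, whether a group other than an aromatic ring at this position, such as an amine, a carboxylic acid or a longer alkyl chain, would shift the number beyond the scatter remains open. Also open, going by these compounds, is what a change to the 3,4-dihydroxy-5-(hydroxymethyl)oxolan-2-yl group would do, since all three compounds carry it unchanged.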